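This account rests on a few compounds, and the source may have more. Where it says the series, first, only, none or still open, it means among the compounds named here.

Measured so far in a functional assay on HL-60 cells (Homo sapiens) for inhibition, read by resazurin assay, with a stated time of 72 h; a higher number here means a weaker inhibitor, a lower number a stronger inhibitor:
Compound 1 `COc1ccc(C2C(O)C(=O)N2c2cc(OC)c(OC)c(OC)c2)cc1`: 13 nM
Compound 2 `COc1ccc(C2C(O)C(=O)N2c2cc(OC)c(OC)c(OC)c2)cc1O`: 5 nM
Compound 3 `CCOc1ccc(C2C(O)C(=O)N2c2cc(OC)c(OC)c(OC)c2)cc1`: 11 nM

Among these three compounds, compound 3 gives 11 nM. Its nearest neighbour shows a 1.2-fold lower number from compound 1 to compound 3 (0.07 log units; within the scatter), while its furthest shows a 2.2-fold higher number from compound 2 to compound 3 (0.34 log units; beyond the scatter).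

The next compound is compound 4 `COc1cc(N2C(=O)C(O)C2c2ccc(SC)cc2)cc(OC)c1OC`, which has not yet been measured. It carries methylsulfanyl in place of ethoxy on an aromatic carbon, para to a large group (methylsulfanyl in place of ethoxy on an aromatic carbon). For the measured compounds named here, no measured step makes this exact exchange. Going by the values given here, the closest precedent changes the ethoxy group itself and shows a 1.2-fold lower number from compound 1 to compound 3 (0.07 log units; within the scatter). The change from compound 1 to compound 2 on the same ring is larger but still modest, showing a 2.6-fold lower number from compound 1 to compound 2 (0.41 log units; beyond the scatter). On this limited evidence, a small step in this assay is expected, probably not beyond the scatter and with no firm direction. The expected change is a 1.4-fold higher number from compound 3 to compound 4 (0.13 log units; within the scatter). Compound 4 is estimated at 15 nM, with an expected range of 5 nM to 45 nM.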

Compound 4, half-maximal inhibitory concentration: 15 nM
Compound 4: the middle estimate sits on the measured number at the digits printed, and the stated range covers the measured number.
By their numbers in this assay, from the lowest: compound 2; then compounds 3, 1 and 4 (each within the scatter of the next).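

In this assay, methylsulfanyl at this position, para to a large group, shows a 1.4-fold higher number from compound 3 to compound 4 (0.13 log units; within the scatter) when it replaces ethoxy and a 1.2-fold higher number from compound 1 to compound 4 (0.06 log units; within the scatter) when it replaces methoxy. Both steps lie within the scatter, so compounds 1, 3 and 4 cannot be told apart, even though the entering group brings sulfur in place of oxygen. Compound 2 still stands apart, with a 3.0-fold higher number from compound 2 to compound 4 (0.48 log units; beyond the scatter) for the change of the whole aryl group, a modest step beyond the scatter, and no supporting data here explain how these groups compare.

From the compounds shown here alone, it remains open whether a dimethylamino group, a carboxylic acid or a longer chain such as butoxy would be tolerated at this position. It is also unknown whether the hydroxy group of compound 2 would give a similar step on the ring of compound 4.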